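The compounds below may be only part of what the source reports. "The series", "measured", "known", "first", "only" and "open" are said of these compounds alone.

Of the compounds shown here, three with a shared core have been measured in a functional assay on CWR22R cells (Homo sapiens) for antiproliferative activity, read by CCK-8 assay, with a stated time of 6 days; a lower number here means a stronger inhibitor, a higher number a weaker inhibitor. Compound 1 `C[C@@H](Cn1ccc(-c2ccc(C#N)c(Cl)c2)n1)Nc1ccccc1` carries phenyl on the amine nitrogen, and its reading of > 30000 nM is a limit of the assay, not a number. Compound 2 `C[C@@H](Cn1ccc(-c2ccc(C#N)c(Cl)c2)n1)Nc1ncccn1`, with pyrimidin-2-yl there instead, gives 12500 nM. The change is an at least 2.4-fold lower number from compound 1 to compound 2 (0.38 log units; beyond the scatter). Compound 3 `C[C@@H](Cn1ccc(-c2ccc(C#N)c(Cl)c2)n1)Nc1ncnc2nc[nH]c12` gives 4240 nM, the lowest number of the three. It stands apart from its neighbours with a 2.9-fold lower number from compound 2 to compound 3 (0.47 log units; beyond the scatter) and with an at least 7.0-fold lower number from compound 1 to compound 3 (0.84 log units; beyond the scatter).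

Compound 4 `C[C@@H](Cn1ccc(-c2ccc(C#N)c(Cl)c2)n1)Nc1nc(Cl)nc2nc[nH]c12` keeps all of compound 3 except for one change: chloro in place of hydrogen on an aromatic carbon. The chloro sits on an aromatic carbon, between two ring nitrogen atoms. Among the measured compounds shown here, no measured step adds a chloro or touches this carbon. All three replace the whole group on the amine nitrogen, so they show only how far numbers in this series have moved. The closest guide is a 2.9-fold lower number from compound 2 to compound 3 (0.47 log units; beyond the scatter), and a single added atom is not expected to exceed that modest size. Going by these compounds, the direction stays open, with a slight lean towards a lower number, and the expected change is a 1.4-fold lower number from compound 3 to compound 4 (0.15 log units; within the scatter). For compound 4 the estimated value in this assay is 3000 nM, with an expected range from 800 nM to 11000 nM.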

Compound 4, half-maximal inhibitory concentration: 4380 nM
The estimate for compound 4 lay 1.5-fold (0.16 log units) below the measured number, within the range that was stated.
By their numbers in this assay, from the lowest: compounds 3 and 4 (each within the scatter of the next); then compound 2. At a limit, above all of these: compound 1.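

In this assay, chloro in place of hydrogen on the aromatic carbon between two ring nitrogen atoms gives no change that can be told apart from the scatter, with a 1.0-fold higher number from compound 3 to compound 4 (0.01 log units; within the scatter). This is the first step shown that touches this carbon; the earlier steps all replaced the whole group on the amine nitrogen, and each of them moved the number beyond the scatter, whereas this single added atom does not. The position therefore carries a chlorine atom with a reading that cannot be separated from that of compound 3, and nothing given here accounts for this result.

Hydrogen and chloro are the only groups shown on this carbon, so what an amine, a methoxy group or a longer chain would do there stays open. Also open, going by these compounds, is whether chloro at this position would give the same result with a different group on the amine nitrogen, as it appears here only in compound 4.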